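This account rests on a few compounds, and the source may have more. Where it says the series, first, only, none or still open, it means among the compounds named here.

Compound 1 `COc1ccc(-c2c(S(=O)(=O)c3cc(F)cc(F)c3)cnc3c(F)cccc23)cc1`: 2.59 mL/min
Compound 2 `O=S(=O)(c1ccc(F)cc1)c1cnc2c(F)cccc2c1-c1cccc(Cl)c1`: 1.21 mL/min
Compound 3 `O=S(=O)(c1cccc(F)c1)c1cnc2c(F)cccc2c1-c1cccc(Cl)c1`: 0.56 mL/min

In an ADME assay on microsomes from liver (Homo sapiens) for metabolic stability, tested at 2.5 uM (a lower number here means slower removal, a higher number faster removal of the compound), compound 3 gives the lowest of the three numbers. Compound 4 `O=S(=O)(c1cc(F)cc(F)c1)c1cnc2c(F)cccc2c1-c1cccc(Cl)c1` differs from compound 3 in one place: fluoro in place of hydrogen on an aromatic carbon. Within the data shown here, no measured step shows exactly this change. The nearest is a 2.2-fold lower number from compound 2 to compound 3 (0.33 log units; beyond the scatter), which moved a single fluoro to a different position on the same ring. Compound 1 carries the 3,5-difluorophenyl of compound 4 but with a different group elsewhere, and it gives the highest number of the three, so its value does not transfer directly. Among the measured compounds shown here, with no matching step, the added fluoro is expected to change the number little, and the step of a 1.3-fold higher number from compound 3 to compound 4 (0.13 log units; within the scatter) is the estimate. Compound 4 is therefore expected at 0.75 mL/min, between 0.35 mL/min and 1.6 mL/min.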

Compound 4, intrinsic clearance in a liver preparation (reported as CLH), per the amount of preparation that the assay uses: 0.64 mL/min
Compound 4: the middle estimate sits 1.2-fold (0.07 log units) above what was measured; the range from low to high includes it.
By their numbers in this assay, from the lowest: compounds 3, 4 and 2 (each within the scatter of the next, the first and the last beyond it); then compound 1.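

In this assay, the second fluoro of the 3,5-difluorophenyl group makes no clear difference, with a 1.1-fold higher number from compound 3 to compound 4 (0.06 log units; within the scatter), and the comparison with the 4-fluorophenyl group, at a 1.9-fold lower number from compound 2 to compound 4 (0.28 log units; within the scatter), also stays within the scatter. Among these compounds, the only step here beyond the scatter lies at the other aromatic group, where 3-chlorophenyl in place of 4-methoxyphenyl gives a 4.0-fold lower number from compound 1 to compound 4 (0.61 log units; beyond the scatter). Nothing available explains these numbers. Still open, as far as these compounds go, is whether a nitrile or an amine in place of the second fluoro would shift the number.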